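A few compounds are considered here, and "the series" means these few. Any claim that something is new, unique, unknown or untested is made for them only; others in the source may bear on it.

The measured compounds, each with its value in a functional assay on MDA-MB-231 cells (Homo sapiens) for cytotoxicity, read by MTT assay, with a stated time of 48 h; a higher number here means a weaker inhibitor, a lower number a stronger inhibitor:
compound 1 `O=C1C[C@H](OCc2cn(Cc3ccc([N+](=O)[O-])cc3)nn2)[C@H]2CO[C@@H]1O2` gives 25400 nM;
compound 2 `O=C1C[C@H](OCc2cc(/C=C/c3ccccc3)no2)[C@H]2CO[C@@H]1O2` gives 22900 nM;
compound 3 `COc1ccc(/C=C/c2cc(CO[C@H]3CC(=O)[C@@H]4OC[C@H]3O4)on2)cc1` gives 26400 nM.

Compound 2 holds the lowest of the three numbers, yet its gaps to compound 1 and to compound 3 both fall within the scatter, so the three stand level. Among the measured compounds shown here, the single measured step, a 1.2-fold higher number from compound 2 to compound 3 (0.06 log units; within the scatter), puts a methoxy in place of hydrogen on an aromatic carbon and also stays within the scatter. Compound 4 `O=C1C[C@H](OCc2cc(-c3ccc(Cl)o3)no2)[C@H]2CO[C@@H]1O2` differs from compound 2 by 5-chlorofuran-2-yl in place of 2-phenylethenyl on an aromatic carbon. For the measured compounds named here, no measured step touches this kind of exchange, so the expectation rests on the level spread of the three values and carries a wide range. Compound 4 is expected to give 25000 nM, between 8000 nM and 80000 nM. That estimate means an expected 1.1-fold higher number from compound 2 to compound 4 (0.04 log units; within the scatter), no step beyond the scatter.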

Compound 4, half-maximal inhibitory concentration: 13800 nM
Compound 4: the middle estimate sits 1.8-fold (0.26 log units) above what was measured, within the range that was stated.
By their numbers in this assay, from the lowest: compounds 4, 2, 1 and 3 (each within the scatter of the next).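

In this assay, replacing the whole 2-phenylethenyl with 5-chlorofuran-2-yl gives a 1.7-fold lower number from compound 2 to compound 4 (0.22 log units; within the scatter). This aromatic carbon of the five-membered ring therefore carries either group with no step beyond the scatter, even though the exchange swaps the six-membered carbon ring for a ring with a hetero atom and removes the double bond outside the rings. Nothing measured here bears on why the two groups stand level.

Still open, as far as these compounds go, is what an amine or a carboxylic acid would do in this place. Also open is whether the chlorine matters, as no unchlorinated furan-2-yl partner is among the compounds shown.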